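Trading methyl for trifluoromethyl: what might change?

This account rests on a few compounds, and the source may have more. Where it says the series, first, only, none or still open, it means among the compounds named here.

- compound 1 `N#Cc1ccc(NC(=O)c2cc(Cl)ccc2O)c(Cl)c1` gives 860 nM
- compound 2 `N#Cc1ccc(NC(=O)c2cccc(Br)c2O)cc1` gives 3260 nM
- compound 3 `Cc1ccc(C(=O)Nc2ccc(C#N)cc2)c(O)c1` gives 2560 nM

In a functional assay on KG-1 cells (Homo sapiens) for cytotoxicity, read by luminescence and CellTiter-Glo, with a stated time of 3 days (on this read-out lower numbers stand for stronger inhibition and higher numbers for weaker inhibition), compound 3 gives 2560 nM and lies within the usual scatter of compound 2 at 3260 nM on the same scale. Compound 1 at 860 nM stands lower than compound 3 by more than that scatter.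

The next compound is compound 4 `N#Cc1ccc(NC(=O)c2ccc(C(F)(F)F)cc2O)cc1` in which trifluoromethyl replaces methyl on an aromatic carbon, meta to a hydroxy group and para to a large group trifluoromethyl in place of methyl on an aromatic carbon with the rest unchanged.

Among the compounds with values here, no two measured compounds differ in one place only, so nothing here tests this swap directly. A small move toward a lower number in this assay is expected, possibly none beyond the scatter, and the uncertainty is wide. The estimated change is a 1.6-fold lower number from compound 3 to compound 4 (0.20 log units; within the scatter) and remains an expectation. For compound 4 the estimated value is 1600 nM and the expected range runs from 650 nM to 3800 nM on this estimate.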

Compound 4, half-maximal inhibitory concentration: 1440 nM
Compound 4: the middle estimate sits 1.1-fold (0.05 log units) above what was measured; the measured number falls inside the stated range.
By their numbers in this assay, from the lowest: compounds 1, 4, 3 and 2 (each within the scatter of the next, the first and the last beyond it).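

Within the data shown here, compound 3 and compound 4 are the first pair here that differ in one place only, so this swap can now be read directly. In this assay trifluoromethyl in place of methyl gives a 1.8-fold lower number from compound 3 to compound 4 (0.25 log units; within the scatter) and so does not separate the two compounds, even though four heavy atoms now stand where one stood on this aromatic carbon, meta to a hydroxy group and para to a large group. No supporting measurement bears on this result.

Going by these compounds, it remains open whether another group on this carbon, such as an amine, a carboxylic acid or a longer chain, would move the number beyond the scatter. The same swap is also untested in the presence of the other substituents seen in compound 1 and compound 2.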